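Methoxy on the anilino ring: a third methoxy and a single one

The source may report more compounds than this note shows. Statements on the series, on what has been measured and on what is new or still open speak of the compounds shown alone.

Compound 1 `COc1cc(Nc2nc3ccccc3nc2S(=O)(=O)c2ccc(C)cc2)cc(OC)c1` gives 2940 nM in a functional assay on PC-3 cells (Homo sapiens) for cytotoxicity, read by MTT assay, with a stated time of 72 h; on this read-out higher numbers stand for weaker inhibition and lower numbers for stronger inhibition. Compound 2 `COc1cc(Nc2nc3ccccc3nc2S(=O)(=O)c2ccc(C)cc2)cc(OC)c1OC`, which carries methoxy in place of hydrogen on an aromatic carbon, gives 4850 nM in this assay, and the step of a 1.6-fold higher number from compound 1 to compound 2 (0.22 log units; within the scatter) is small. Compound 3 `O=S(=O)(c1ccc(Br)cc1)c1nc2ccccc2nc1Nc1ccccc1` gives 1180 nM, the lowest of the three numbers; the difference between the core of compound 3 and the core of compound 1 is not broken down here, so the gap between their values is noted without a counted change.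

Compound 4 `COc1ccc(Nc2nc3ccccc3nc2S(=O)(=O)c2ccc(Br)cc2)cc1` has not yet been measured in this assay. It differs from compound 3 by methoxy in place of hydrogen on an aromatic carbon. This is the same kind of change as that from compound 1 to compound 2, though the surroundings differ: there the entering methoxy sat ortho to two methoxy groups and para to a large group, here it sits only para to a large group. Resting on the step of a 1.6-fold higher number from compound 1 to compound 2 (0.22 log units; within the scatter), the step of a 1.3-fold higher number from compound 3 to compound 4 (0.10 log units; within the scatter) is expected to be small. Compound 4 is accordingly estimated at 1500 nM, with a range from 600 nM to 3800 nM.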

Compound 4, half-maximal inhibitory concentration: 1110 nM
Beside the measured number, compound 4's estimate is 1.4-fold (0.13 log units) above it; the range from low to high includes it.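

In this assay, methoxy in place of hydrogen on an aromatic carbon gives a 1.1-fold lower number from compound 3 to compound 4 (0.03 log units; within the scatter), so on this core the 4-methoxyphenyl group and the phenyl group cannot be told apart. Carried from one core to the other, the change stays small on both, and the two steps cannot be separated: the same change on two cores in this assay, a 1.6-fold higher number (0.22 log units; within the scatter) from compound 1 to compound 2 and a 1.1-fold lower number (0.03 log units; within the scatter) from compound 3 to compound 4, 1.8-fold (0.24 log units) apart, within the scatter of two such steps. This supports only a limited reading for these two pairs: it does not establish a rule for the series, does not explain why the steps are small, and does not tell how much of the surroundings of the entering methoxy matters.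

As far as these compounds go, it remains open whether a different group in the place para to a large group, such as an amine, a carboxylic acid or a longer chain such as butoxy, would move the value beyond the scatter. Also open, from the compounds shown here alone, is whether the small step would hold on cores other than these two.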